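A few compounds are considered here, and "the series" means these few. Any claim that something is new, unique, unknown or untested is made for them only; others in the source may bear on it.

Compound 1 `CCN(CC)c1cc2[nH]c(C3CCCCC3)nc2cc1NC(=O)OCC(F)(F)F` gives > 100 ug/mL in an ADME assay on Vero cells (Chlorocebus sabaeus) for cytotoxicity, read by resazurin assay, with a stated time of 3 days (on this read-out higher numbers stand for weaker inhibition and lower numbers for stronger inhibition), which is a limit of the assay and not a number. Compound 2 `CCCCCC(=O)Nc1cc2nc(C3CCCCC3)[nH]c2cc1N(CC)CC` gives "not determined" (no result reported) in this assay. Compound 3 `CCCOCC(=O)Nc1cc2nc(C3CCCCC3)[nH]c2cc1N(CC)CC` gives > 100 ug/mL in this assay, again a limit of the assay.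

Compound 3 therefore stands at a limit rather than at a measured number, and of the three entries only its own and that of compound 1 carry any value at all, both of them limits. The step that the two limits leave unreadable from compound 1 to compound 3 accordingly cannot be read as a size in either direction. Compound 4 `CCOc1ccc(C(=O)Nc2cc3nc(C4CCCCC4)[nH]c3cc2N(CC)CC)cc1` differs from compound 3 in one place: 4-ethoxyphenyl in place of propoxymethyl on a carbonyl carbon. Among the measured compounds shown here, no measured step speaks to this exchange of a propoxymethyl for a 4-ethoxyphenyl on the carbonyl carbon; the one step available, a step that the two limits leave unreadable from compound 1 to compound 3, is unreadable. Because (the limit of > 100 ug/mL in this assay, at which 2 of the 3 values shown sit), compound 4 is expected to sit at the same limit, a step of a number no higher from compound 3 to compound 4 (the limit leaves the size open) of no readable size. The estimate for compound 4 in this assay is 100 ug/mL, between 50 ug/mL and 200 ug/mL.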

Compound 4, half-maximal inhibitory concentration: > 100 ug/mL
Compound 4: no number, only a limit; the forecaster's own chance of this, stated with the estimate: 75%; the middle value sits exactly at the limit.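

Among the compounds shown here, compound 4 gives > 100 ug/mL in this assay, a limit of the assay and not a number, and no step from compound 1 or compound 3 to compound 4 can be read. The compounds shown leave open whether the exchanges on the carbonyl carbon change this read-out at all, and where compound 2 stands.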